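The source may hold more compounds than are shown below. What is called first, only, known or untested is meant among the compounds shown, and "the series" means these compounds.

Working notes on the oxazolidinone series

The shared core is shown by compound 1 `COC(=O)CC1CCN(C[C@H]2CN(c3ccc(-n4cc(-c5ccccn5)cn4)c(F)c3)C(=O)O2)CC1`, which carries 4-((methoxycarbonyl)methyl)piperidin-1-yl on a saturated chain carbon bound to a saturated ring carbon. In an ADME assay on HEK293-A cells (Homo sapiens) for cytotoxicity, read by MTT assay, with a stated time of 48 h (on this read-out higher numbers stand for weaker inhibition and lower numbers for stronger inhibition), compound 1 gives 224 ug/mL. Compound 2 `O=C(OC[C@H]1CN(c2ccc(-n3cc(-c4ccccn4)cn3)c(F)c2)C(=O)O1)c1ccccc1` carries benzoyloxy at that chain carbon. In this assay compound 2 reaches only a limit of the assay, > 400 ug/mL. Compound 3 `O=CNC[C@H]1CN(c2ccc(-n3cc(-c4ccccn4)cn3)c(F)c2)C(=O)O1` carries formylamino at the same chain carbon. In this assay compound 3 likewise gives only a limit, > 400 ug/mL. Compound 3 therefore stands at the top of the numbers shown, on the limit of > 400 ug/mL in this assay, at which 2 of the 3 values shown sit, together with compound 2.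

From the compounds shown here alone, the measured steps read an at least 1.7-fold higher number from compound 1 to compound 2 (0.25 log units; that floor lies within the scatter) and an at least 1.7-fold higher number from compound 1 to compound 3 (0.25 log units; that floor lies within the scatter), while a step that the two limits leave unreadable from compound 2 to compound 3 stays open.

Compound 4 `COC(=O)NC[C@H]1CN(c2ccc(-n3cc(-c4ccccn4)cn3)c(F)c2)C(=O)O1` is the next step, (methoxy in place of hydrogen on a carbonyl carbon); in other words formylamino becomes (methoxycarbonyl)amino. Within the data shown here, no measured pair changes that carbonyl carbon, so the only bearing comes from compound 3 itself, whose limit > 400 ug/mL is the starting point. Within this assay the expectation for compound 4 is a number no higher from compound 3 to compound 4 (the limit leaves the size open), that is no step beyond the scatter, most likely another limit. The estimate for compound 4 in this assay is 400 ug/mL, with a range from 200 ug/mL to 800 ug/mL.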

Compound 4, half-maximal inhibitory concentration: 306 ug/mL
Beside the measured number, compound 4's estimate is 1.3-fold (0.12 log units) above it; measured number inside the range.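

The step for methoxy in place of hydrogen on a carbonyl carbon reads as an at least 1.3-fold lower number from compound 3 to compound 4 (0.11 log units; that floor lies within the scatter), and the change from benzoyloxy to (methoxycarbonyl)amino on the chain carbon reads as an at least 1.3-fold lower number from compound 2 to compound 4 (0.11 log units; that floor lies within the scatter), so in this assay neither change is shown to go beyond the scatter. Among these compounds, the series now also has a 1.4-fold higher number from compound 1 to compound 4 (0.14 log units; within the scatter), the first step at this chain carbon with a number at both ends, and it leaves (methoxycarbonyl)amino and 4-((methoxycarbonyl)methyl)piperidin-1-yl not told apart. Compound 2 and compound 3 stay as limits of the assay, and the step between them cannot be read: the limit of > 400 ug/mL in this assay, at which 2 of the 4 values shown sit.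

From the compounds shown here alone, whether a free amine or a carboxylic acid on the chain carbon, or ethoxy or a longer chain in place of methoxy on the carbonyl carbon, would give a step beyond the scatter stays open. Going by these compounds, the full size of the step from hydrogen to methoxy also stays open while compound 3 is held at a limit.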